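The compounds below may be only part of what the source reports. "The series", "measured", "known", "first", "only" and "open" are said of these compounds alone.

The measured compounds:
Compound 1, `CCCCCCCCCc1nc(O)cc(O)n1`, in a functional assay on HEK293 cells for agonist activity at G-protein coupled receptor 84 (Homo sapiens), read by calcium flux (a lower number here means a smaller maximal response, a higher number a larger maximal response), compound 1 gives 84.1%.
Compound 2, `CCCCCCCCc1cc(O)cc(O)n1`, gives 82.6%.
Compound 3, `CCCCCCCCc1nc(O)cc(O)n1`, gives 110%.

Compound 1 and compound 3 share one core; compound 3 carries hydrogen in place of methyl on a saturated chain carbon, eight bonds along the chain from an aromatic carbon, and that step raised the maximal response: a number 25.9 percentage points higher from compound 1 to compound 3 (beyond the scatter). Compound 2 rests on a different core; how the two cores differ is not broken down here. Compound 4, `CCCCCCCc1cc(O)cc(O)n1`, has not yet been measured. Compound 4 stands to compound 2 as compound 3 stands to compound 1, with hydrogen in place of methyl on a saturated chain carbon, seven bonds along the chain from an aromatic carbon; the place is seven bonds along the chain rather than eight, so this is the same kind of change, not the same. The step from compound 2 to compound 4 is expected to be a number 15.4 percentage points higher from compound 2 to compound 4 (beyond the scatter), smaller than the earlier one, because a number 25.9 percentage points higher from compound 1 to compound 3 (beyond the scatter) rests on a single pair on another core. Compound 4 is expected to reach 98%, likely between 82% and 114%.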

Compound 4, largest response reached (reported as percent of maximum), in percent of the reference or control that the assay uses: 87.8%
For compound 4 the middle estimate is 10.2 percentage points above the measured one; low and high end bracket the measured number.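

Putting hydrogen in place of methyl on the saturated chain gives, in this assay, a number 5.2 percentage points higher from compound 2 to compound 4 (within the scatter), a step that cannot be told apart from the scatter of repeat measurements. The same kind of change therefore did not carry over in size from one core to the other: the same change on two cores in this assay, a number 25.9 percentage points higher (beyond the scatter) from compound 1 to compound 3 and a number 5.2 percentage points higher (within the scatter) from compound 2 to compound 4, 20.7 percentage points apart, beyond the scatter of two such steps

Among the compounds shown here, each core offers only one pair, and the place on the chain is seven bonds along rather than eight, so these results cannot separate the effect of the core from that of the chain position. They also say nothing about other cores.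

The compounds shown leave open how a longer chain would behave on either core. From the compounds shown here alone, an amine or a carboxylic acid on the chain also remains open.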